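The compounds below may be only part of what the source reports. "The series", "measured", "known", "first", "only" and "open" are said of these compounds alone.

Compound 1 `CCC(C)(C)/N=C(\NC#N)Nc1ccc(I)cc1` gives 74 nM in an assay on membranes from heart (Canis lupus familiaris) for displacement of a labelled ligand from sulfonylurea receptor 2, Kir6.2 (Homo sapiens); on this read-out higher numbers stand for weaker inhibition and lower numbers for stronger inhibition.
Compound 2 `CC(C)/N=C(\NC#N)Nc1ccc(C#N)cc1` gives 7300 nM in this assay.
Compound 3 `C/N=C(\NC#N)Nc1ccc(C#N)cc1` gives > 30000 nM, which is a limit of the assay rather than a number.

Compound 3 therefore stands only at a limit (the limit of > 30000 nM in this assay, at which 1 of the 3 values shown sits), with no number of its own. Compound 4 `CCC(C)(C)/N=C(\NC#N)Nc1ccc(C#N)cc1` has not been measured yet; it differs from compound 3 by 1,1-dimethylpropyl in place of methyl on a double-bonded nitrogen. Within the data shown here, the one measured step that bears on this position runs the other way, from isopropyl to methyl, and gave an at least 4.1-fold higher number from compound 2 to compound 3 (0.61 log units; beyond the scatter). Putting a larger group on the double-bonded nitrogen is therefore expected to lower the number, toward stronger inhibition, by about an at least 20-fold lower number from compound 3 to compound 4 (1.30 log units; beyond the scatter). Among the measured compounds shown here, compound 1 carries the same 1,1-dimethylpropyl group, with iodine instead of a nitrile, and shows 74 nM, but no single-change step joins it to compound 4. Compound 4 is estimated at 1500 nM, with a likely range from 300 nM to 8000 nM.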

Compound 4, inhibition constant: 160 nM
Compound 4: the middle estimate sits 9.4-fold (0.97 log units) above what was measured; measured number below the stated range.
By their numbers in this assay, from the lowest: compound 1; then compound 4; then compound 2. At a limit, above all of these: compound 3.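

Moving from isopropyl to 1,1-dimethylpropyl on the double-bonded nitrogen still gives a 46-fold lower number from compound 2 to compound 4 (1.66 log units; beyond the scatter), so the gain does not stop at isopropyl, and starting from methyl the change gives an at least 180-fold lower number from compound 3 to compound 4 (2.27 log units; beyond the scatter). Compound 3 stands only at a limit, so that second step is a bound: the limit of > 30000 nM in this assay, at which 1 of the 4 values shown sits. Cyano in place of iodo on an aromatic carbon gives only a 2.2-fold higher number from compound 1 to compound 4 (0.33 log units; beyond the scatter) as a much smaller step than those on the nitrogen.

On these data alone, whether a longer chain or a cyclohexyl ring on that nitrogen would lower the number further stays open. So does how an amine would behave in place of the nitrile.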